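Removing a Bromo Group from a Second Indole Series

The source may hold more compounds than are shown below. What is called first, only, known or untested is meant among the compounds shown, and "the series" means these compounds.

Of the compounds shown here, three have been tested in a functional assay on PC-3 cells (Homo sapiens) for cytotoxicity; on this read-out higher numbers stand for weaker inhibition and lower numbers for stronger inhibition. Compound 1 `COc1ccc2c(c1)c(/C=N\NC(=O)c1c[nH]c3ccc(Br)cc13)cn2Cc1ccc(Cl)cc1` gives 15900 nM in this assay. Compound 2 `COc1ccc2c(c1)c(/C=N\NC(=O)c1c[nH]c3ccccc13)cn2Cc1ccc(Cl)cc1` is made from compound 1 by a single change, described as hydrogen in place of bromo on an aromatic carbon, and in this assay compound 2 gives 30300 nM. The step is a 1.9-fold higher number from compound 1 to compound 2 (0.28 log units; within the scatter), so the two numbers cannot be told apart with confidence.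

Compound 3 `COc1ccc(Cn2cc(/C=N\NC(=O)c3c[nH]c4ccc(Br)cc34)c3ccc(F)cc32)cc1` carries a different core; how its core differs from that of compound 1 is not broken down here. In this assay compound 3 gives 21800 nM, which sits close to the numbers of compound 1 and compound 2.

Compound 4 `COc1ccc(Cn2cc(/C=N\NC(=O)c3c[nH]c4ccccc34)c3ccc(F)cc32)cc1` has not yet been measured. It stands to compound 3 as compound 2 stands to compound 1: the difference is hydrogen in place of bromo on an aromatic carbon. The surroundings of the changed atom are described in the same words for both pairs, so this is the same change made for the second time among these compounds.

Going by the values given here, the only guide to what compound 4 will show is the step from compound 1 to compound 2. The step from compound 3 to compound 4 is therefore expected to be a 1.8-fold higher number from compound 3 to compound 4 (0.26 log units; within the scatter), resting on compound 1 and compound 2 having given a 1.9-fold higher number from compound 1 to compound 2 (0.28 log units; within the scatter). On that basis compound 4 is estimated to give 40000 nM in this assay, with a plausible range from 15000 nM to 100000 nM.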

Compound 4, half-maximal inhibitory concentration: 18400 nM
Beside the measured number, compound 4's estimate is 2.2-fold (0.34 log units) above it, within the range that was stated.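

Putting hydrogen in place of bromo on the core of compound 3, which turns 5-bromo-1H-indol-3-yl into 1H-indol-3-yl, gives in this assay a 1.2-fold lower number from compound 3 to compound 4 (0.07 log units; within the scatter), so these two numbers cannot be told apart with confidence. The earlier step on the core of compound 1 could not be told from the scatter either, and the two steps do not differ from each other by more than repeated measurements could: the same change on two cores in this assay, a 1.9-fold higher number (0.28 log units; within the scatter) from compound 1 to compound 2 and a 1.2-fold lower number (0.07 log units; within the scatter) from compound 3 to compound 4, 2.3-fold (0.35 log units) apart, within the scatter of two such steps What this shows is that the change carries across these two cores without a readable effect in this assay, but it does not show that bromo and hydrogen are truly equivalent, since two pairs are few and a modest real effect could hide within steps of this size.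

From the compounds shown here alone, it remains open whether a different group on that same aromatic carbon, such as chloro, methoxy, an amine or a carboxylic acid, would give a number clearly apart from these. Going by these compounds, it is also open whether the same swap on a third core, or in a read-out other than this assay, would behave as it does here.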